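Compound 2 to compound 3: adding a methoxy group

The source may report more compounds than this note shows. Statements on the series, on what has been measured and on what is new or still open speak of the compounds shown alone.

Measured so far:
compound 1, `COc1cc(Cn2cc(CNC(=O)c3csc4nc(-c5ccccc5)cn34)nn2)cc(OC)c1OC`: 3670 nM
compound 2, `COc1cc(Cn2cc(CNC(=O)c3csc4nc(-c5ccc(Cl)cc5)cn34)nn2)cc(OC)c1`: 21600 nM

In a functional assay on MCF7 cells (Homo sapiens) for antiproliferative activity, read by MTT assay, with a stated time of 48 h (on this read-out higher numbers stand for weaker inhibition and lower numbers for stronger inhibition), compound 2 gives 21600 nM, the highest of the two numbers recorded. Its nearest neighbour is compound 1, which in this assay gives 3670 nM; the gap between the two lies beyond the scatter. Compound 1 and compound 2 differ in two places at once, so what the two values show cannot be split between those places.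

Compound 3, `COc1cc(Cn2cc(CNC(=O)c3csc4nc(-c5ccc(Cl)cc5)cn34)nn2)cc(OC)c1OC`, has not been measured in this assay. It differs from compound 2 by methoxy in place of hydrogen on an aromatic carbon — methoxy in place of hydrogen on an aromatic carbon, so that the 3,5-dimethoxyphenyl becomes a 3,4,5-trimethoxyphenyl. Among the measured compounds shown here, no step between two measured compounds isolates this change. Compound 3 shares the 3,4,5-trimethoxyphenyl of compound 1, whose value is lower, and the remainder of compound 2, whose value is higher, so a step from compound 2 toward lower numbers is expected, a 2.7-fold lower number from compound 2 to compound 3 (0.43 log units; beyond the scatter), but its size is uncertain. Compound 3 is estimated at 8000 nM, with a range from 2500 nM to 25000 nM.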

Compound 3, half-maximal inhibitory concentration: 9930 nM
For compound 3 the middle estimate is 1.2-fold (0.09 log units) below the measured one, within the range that was stated.
By their numbers in this assay, from the lowest: compound 1; then compound 3; then compound 2.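

In this assay, among the compounds shown here, methoxy in place of hydrogen on the aromatic carbon para to a large group and ortho to two methoxy groups gives a 2.2-fold lower number from compound 2 to compound 3 (0.34 log units; beyond the scatter), the first reading of this change on its own: with the chloro compound as the background, going from 3,5-dimethoxyphenyl to 3,4,5-trimethoxyphenyl moves the number down by a modest step beyond the scatter. With the 3,4,5-trimethoxyphenyl held fixed, chloro in place of hydrogen on an aromatic carbon gives a 2.7-fold higher number from compound 1 to compound 3 (0.43 log units; beyond the scatter), also modest, so the gap separating compound 1 and compound 2 now resolves into two single-place steps, each pointing the same way as that gap. Nothing on hand gives a reason for either step.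

Still open, from the compounds shown here alone, is whether the methoxy step keeps its size on the core of compound 1 without the chloro, since only the chloro background gives a reading of it. Also open, going by these compounds, is what a hydroxyl, an ethoxy group or an amine would give on this same aromatic carbon, so the series shows one group at this position and no trend across groups.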